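Sulfonyl aryl change in the pyridazine sulfonamide series

The source may hold more compounds than are shown below. What is called first, only, known or untested is meant among the compounds shown, and "the series" means these compounds.

For the measured compounds named here, compound 1 `Cc1ccc(S(=O)(=O)Nc2ccc(-c3ccccc3N3CCCC3)nn2)cc1` gives 1.7 nM in an assay on mitochondria from liver for inhibition of kynurenine 3-monooxygenase (Mus musculus), read by LC-MS, with stated times of 5 min and 30 min (a higher number here means a weaker inhibitor, a lower number a stronger inhibitor), the lowest of the two numbers so far; compound 2 `CCc1ccccc1-c1ccc(NS(=O)(=O)c2ccc(C)cc2)nn1` gives 29.2 nM, and the step of a 17-fold higher number from compound 1 to compound 2 (1.23 log units; beyond the scatter) concerns the other aromatic ring. Compound 3 `CN(C)c1cccc(S(=O)(=O)Nc2ccc(-c3ccccc3N3CCCC3)nn2)c1` differs from compound 1 by 3-(dimethylamino)phenyl in place of 4-methylphenyl on a sulfonyl sulfur. Going by the values given here, no measured step touches the group on the sulfonyl sulfur, so the measured step from compound 1 to compound 2 does not bear on this change, and nothing beyond the scatter is expected in either direction in this assay. The number for compound 3 is estimated at 3 nM, between 0.7 nM and 15 nM, the expected step being a 1.8-fold higher number from compound 1 to compound 3 (0.25 log units; within the scatter).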

Compound 3, half-maximal inhibitory concentration: 3.3 nM
Estimate against measurement, compound 3: 1.1-fold (0.04 log units) below; low and high end bracket the measured number.
By their numbers in this assay, from the lowest: compounds 1 and 3 (each within the scatter of the next); then compound 2.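

In this assay, 3-(dimethylamino)phenyl in place of 4-methylphenyl on the sulfonyl sulfur gives a 1.9-fold higher number from compound 1 to compound 3 (0.29 log units; within the scatter), so the two compounds cannot be told apart. For the compounds shown here, this is the first reading at this position, and it shows that the larger group, with its added nitrogen, keeps the number in the range of compound 1. No evidence at hand bears on the reason for this result.

Going by these compounds, whether a pyridine ring or a carboxylic acid on the aryl ring would read alike remains open. Also open, on these data alone, is whether 3-(dimethylamino)phenyl would hold with ethyl in place of pyrrolidin-1-yl, as in compound 2.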